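Compound 3 to compound 4: swapping the sulfur substituent

A few compounds are considered here, and "the series" means these few. Any claim that something is new, unique, unknown or untested is made for them only; others in the source may bear on it.

In a functional assay on HeLa cells (Homo sapiens) for inhibition, read by CCK-8 assay, with a stated time of 72 h, tested at 8 uM (a lower number here means less inhibition of growth, a higher number more inhibition of growth at the concentration tested), compound 3 (`CCc1ccc(SCc2ccc(C(=O)Nc3ccccc3N)cc2)cc1`) gives 71% and compound 2 (`COc1ccc(SCc2ccc(C(=O)Nc3ccccc3N)cc2)cc1`) gives 79.7%, two values within the scatter of each other. Compound 1 (`Nc1ccccc1NC(=O)/C=C/c1ccc(CSc2cccc(F)c2)cc1`) gives 18.6%, far lower than both. Compound 4 (`Nc1ccccc1NC(=O)c1ccc(CSc2cccc(F)c2)cc1`) has 3-fluorophenyl in place of 4-ethylphenyl on a sulfur. Within the data shown here, the one measured step that bears on this, a number 8.7 percentage points lower from compound 2 to compound 3 (within the scatter), changes only a substituent on that same aromatic ring and stays within the scatter. Among the measured compounds shown here, compound 1 also carries 3-fluorophenyl on a sulfur, but it differs from compound 4 elsewhere, so no measured step isolates this swap. The expected size is a number 3 percentage points lower from compound 3 to compound 4 (within the scatter), with no change beyond the scatter anticipated. For compound 4 the estimate is 68%, with an expected range of 48% to 84%.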

Compound 4, percent growth inhibition at one concentration: 78.4%
Beside the measured number, compound 4's estimate is 10.4 percentage points below it, within the range that was stated.
By their numbers in this assay, from the lowest: compound 1; then compounds 3, 4 and 2 (each within the scatter of the next).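

In this assay the group on the sulfur can change from a 4-substituted ring to 3-fluorophenyl without a step beyond the scatter, whether it replaces 4-ethylphenyl (a number 7.4 percentage points higher from compound 3 to compound 4 (within the scatter)) or 4-methoxyphenyl (a number 1.3 percentage points lower from compound 2 to compound 4 (within the scatter)). Among these compounds, compounds 2, 3 and 4 therefore cannot be separated at this position, and no compound among them goes against that reading. Nothing at hand accounts for this tolerance.

From the compounds shown here alone, whether an unsubstituted phenyl, a cyclohexyl ring or a longer alkyl chain on the sulfur would hold this level stays open. So does the outcome for a ring carrying an amine or a carboxylic acid.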